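Trimming the hydroxycarbamoyl chain of compound 3

The source may hold more compounds than are shown below. What is called first, only, known or untested is meant among the compounds shown, and "the series" means these compounds.

In a functional assay on HEL cells (Homo sapiens) for inhibition (a higher number here means a weaker inhibitor, a lower number a stronger inhibitor), compound 3 `CC(C)c1cc(-c2n[nH]c(=O)n2-c2cccc(NC(=O)CCCCCCC(=O)NO)c2)c(O)cc1O` gives 1600 nM, level with compound 1 `CC(C)c1cc(-c2n[nH]c(=O)n2-c2cccc(NC(=O)CCCCCC(=O)NO)c2)c(O)cc1O` at 1600 nM. These two share the lowest number of the three measured, and compound 2 `CC(C)c1cc(-c2n[nH]c(=O)n2-c2cccc(C(=O)NCCCC(=O)NO)c2)c(O)cc1O` gives 4600 nM. Compound 4 `CC(C)c1cc(-c2n[nH]c(=O)n2-c2cccc(NC(=O)CCCCC(=O)NO)c2)c(O)cc1O` departs from compound 3 by hydroxycarbamoyl in place of 2-(hydroxycarbamoyl)ethyl on a saturated chain carbon, four bonds along the chain from a carbonyl carbon. Within the data shown here, the only measured step along this chain shows no change at the digits printed from compound 1 to compound 3 (within the scatter). Among the measured compounds shown here, compound 2 offers no measured step to compound 3. A change beyond the scatter is therefore not expected, and the estimated step is a 1.3-fold higher number from compound 3 to compound 4 (0.10 log units; within the scatter). Compound 4 is estimated at 2000 nM, with an expected range of 900 nM to 4500 nM.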

Compound 4, half-maximal inhibitory concentration: 1600 nM
The estimate for compound 4 lay 1.3-fold (0.10 log units) above the measured number; the measured number falls inside the stated range.
By their numbers in this assay, from the lowest: compounds 1, 3 and 4 (each within the scatter of the next); then compound 2.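

In this assay the chain shortens further with no change at the digits printed from compound 3 to compound 4 (within the scatter) and no change at the digits printed from compound 1 to compound 4 (within the scatter) so the level stretch now takes in three chain lengths. Among these compounds, by contrast, a 2.9-fold lower number from compound 2 to compound 4 (0.46 log units; beyond the scatter) and this is the first step here beyond the scatter, with ((4-(hydroxycarbamoyl)butyl)carbonyl)amino in place of (3-(hydroxycarbamoyl)propyl)carbamoyl on an aromatic carbon. Nothing available explains either result.

From the compounds shown here alone, whether a chain shorter than that of compound 4 would stay level in this assay remains open. So does the effect of a carboxylic acid in place of hydroxycarbamoyl.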